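The source may report more compounds than this note shows. Statements on the series, on what has been measured and on what is new or still open speak of the compounds shown alone.

Going by the values given here, compound 3 `Brc1ccc(C2=NN(C3=NC(c4ccccc4)CS3)C(c3cccc4ccccc34)C2)cc1` gives 17400 nM in a functional assay on BGC-823 cells (Homo sapiens) for inhibition, read by CCK-8 assay, with a stated time of 48 h (a lower number here means a stronger inhibitor, a higher number a weaker inhibitor), the second highest of the three numbers known here. Compound 1 `Fc1ccc(C2=NN(C3=NC(c4ccccc4)CS3)C(c3cccc4ccccc34)C2)cc1` gives 22700 nM, and the step of a 1.3-fold lower number from compound 1 to compound 3 (0.12 log units; within the scatter) lies within the scatter. Differing from compound 3 in two places, compound 2 `COc1ccc(C2=NN(C3=NC(=O)CS3)C(c3cccc4ccccc34)C2)cc1` gives 8210 nM, a lower number than that of compound 3. Compound 4 `COc1ccc(C2=NN(C3=NC(c4ccccc4)CS3)C(c3cccc4ccccc34)C2)cc1` arises from compound 3 by methoxy in place of bromo on an aromatic carbon. Among the compounds with values here, no measured step exchanges a halogen for a methoxy group on this ring, and the only single-point step known, from compound 1 to compound 3, was within the scatter. Compound 4 is therefore expected to move little, with a 1.2-fold lower number from compound 3 to compound 4 (0.06 log units; within the scatter), and its estimated value is 15000 nM, in a range from 6000 nM to 35000 nM.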

Compound 4, half-maximal inhibitory concentration: 9510 nM
Compound 4: middle estimate off by 1.6-fold (0.20 log units), on the high side; low and high end bracket the measured number.
By their numbers in this assay, from the lowest: compounds 2, 4, 3 and 1 (each within the scatter of the next, the first and the last beyond it).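

On this aromatic carbon, methoxy stands clear of fluoro (a 2.4-fold lower number from compound 1 to compound 4 (0.38 log units; beyond the scatter)) but not of bromo (a 1.8-fold lower number from compound 3 to compound 4 (0.26 log units; within the scatter)), so the halogen pair alone had not shown any step beyond the scatter at this position. With methoxy held in place, exchanging the group on the amine nitrogen in a ring also stays within the scatter (a 1.2-fold higher number from compound 2 to compound 4 (0.06 log units; within the scatter)). Nothing measured here explains these steps. From the compounds shown here alone, whether an amine, a hydroxyl or a nitrile at this position would separate from methoxy remains open. So does the effect of the group on the amine nitrogen when bromo or fluoro sits on the ring.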